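The source may hold more compounds than are shown below. What is called first, only, known or untested is meant among the compounds shown, and "the series" means these compounds.

Measured compounds:
- Compound 1, `Cc1cc(C)c(S(=O)(=O)N2CCN(C3CCN(C)CC3)CC2)c(C)c1`: 426 nM
- Compound 2, `CC1CCN(C2CCN(S(=O)(=O)c3ccc(Cl)nc3)CC2)CC1`: 3700 nM
- Compound 3, `Cc1cc(C)c(S(=O)(=O)N2CCC(N3CCC(Cc4ccc(F)cc4)CC3)CC2)c(C)c1`: 18 nM

All three were tested in a functional assay on DLD-1 cells (Homo sapiens) for antiproliferative activity, read by CellTiter-Glo, with a stated time of 72 h; on this read-out lower numbers stand for stronger inhibition and higher numbers for weaker inhibition. Compound 2 gives 3700 nM, the highest of the three numbers; compound 1, the nearest, sits well below it, and compound 3, the furthest, lies far below it, so compound 2 is the weakest inhibitor among them. Compounds 1 and 3 differ from compound 2 both on the sulfonyl and in the amine part, so no single change explains the gap.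

Compound 4, `CC1CCN(C2CCN(S(=O)(=O)c3ccc(Cl)c(Cl)c3)CC2)CC1`, is not yet measured in this assay. It differs from compound 2 in one place: 3,4-dichlorophenyl in place of 6-chloropyridin-3-yl on a sulfonyl sulfur. Among the measured compounds shown here, since no measured pair shows this change alone, its size is uncertain. A modest downward step from compound 2 to compound 4 is expected, though a step within the scatter is also plausible. The expected step from compound 2 to compound 4 is a 2.5-fold lower number from compound 2 to compound 4 (0.39 log units; beyond the scatter). Compound 4 is estimated at 1500 nM, in the range from 400 nM to 5000 nM.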

Compound 4, half-maximal inhibitory concentration: 2.9 nM
Estimate against measurement, compound 4: 520-fold (2.71 log units) above; measured number below the stated range.
By their numbers in this assay, from the lowest: compound 4; then compound 3; then compound 1; then compound 2.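

Within this assay, exchanging 6-chloropyridin-3-yl for 3,4-dichlorophenyl on the sulfonyl sulfur, with the rest of the molecule unchanged, gives a 1300-fold lower number from compound 2 to compound 4 (3.11 log units; beyond the scatter). Among the compounds shown here, this is the first pair here that differs in only one place, so it shows that the group on this sulfur alone can move the number by a very large amount, which compounds differing in two places could not show. The exchange removes the ring nitrogen and adds a second chlorine, and no measurement shown here explains the size of the step.

A plain phenyl or a phenyl carrying a single chlorine on the same sulfur would help to separate those two differences. On these data alone, whether 3,4-dichlorophenyl gives a step of this size with other amine parts, such as that of compound 1, also stays open.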